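The source may report more compounds than this note shows. Statements on the series, on what has been measured and on what is new or still open speak of the compounds shown alone.

Measured so far:

Compound 1, `CC(C)(C)c1ccc(CS(=O)(=O)/C=C/c2ccc(O)c(O)c2)cc1`: 4.7 10^-6 cm/s
Compound 2, `O=S(=O)(/C=C/c1ccc(O)c(O)c1)Cc1ccc(C(F)(F)F)cc1`: 4.3 10^-6 cm/s
Compound 3, `CC(C)(C)c1ccc(C[S+]([O-])/C=C/c2ccc(O)c(O)c2)cc1`: 5.8 10^-6 cm/s

The three compounds were measured in a physicochemical assay for permeability, using PAMPA, with a stated time of 18 h, tested at 5 mg/mL; on this read-out higher numbers stand for higher permeability and lower numbers for lower permeability. Compound 1 and compound 2 differ in one place only: trifluoromethyl in place of tert-butyl on an aromatic carbon. That change gave a 1.1-fold lower number from compound 1 to compound 2 (0.04 log units; within the scatter), so the two numbers are practically the same. Compound 3 has a different core from compound 1; the difference between the two cores is not broken down here. Its number in this assay sits close to those of compound 1 and compound 2, all three within the usual scatter of one another, so no order among them can be read from the data.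

Compound 4, `[O-][S+](/C=C/c1ccc(O)c(O)c1)Cc1ccc(C(F)(F)F)cc1`, has not yet been measured. It stands to compound 3 as compound 2 stands to compound 1: trifluoromethyl in place of tert-butyl on an aromatic carbon. The place of the change is the same in both pairs, so this is the same change made on the other core. Going by the values given here, the only guide to its size is the step from compound 1 to compound 2, and since that step stayed within the scatter, the step from compound 3 to compound 4 in this assay is expected to be about as small, a 1.1-fold lower number from compound 3 to compound 4 (0.04 log units; within the scatter). On this basis compound 4 is expected to give 5.3 10^-6 cm/s. For compound 4 the expected range runs from 3.5 10^-6 cm/s to 8 10^-6 cm/s.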

Compound 4, apparent permeability: 4.2 10^-6 cm/s
For compound 4 the middle estimate is 1.3-fold (0.10 log units) above the measured one; measured number inside the range.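

Within this assay the new step is a 1.4-fold lower number from compound 3 to compound 4 (0.14 log units; within the scatter) for trifluoromethyl in place of tert-butyl on an aromatic carbon, and the earlier step on the core of compound 1 is a 1.1-fold lower number from compound 1 to compound 2 (0.04 log units; within the scatter) for the same change. On both cores the change therefore leaves the read-out inside the normal spread of repeat measurements, which shows that a step too small to read on one core remained too small to read on the other, but two pairs cannot establish a general rule for this series, and steps this small cannot show whether the core alters the effect of the change. Nothing in the data available explains why the numbers stay so close on either core.

The compounds shown have only tert-butyl and trifluoromethyl at this place, leaving open what an amine, a carboxylic acid or a longer alkyl chain there would do on either core. It also remains open whether a step clearly larger than the normal spread would carry from one core to the other, as no such step appears among these four compounds.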